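The compounds below may be only part of what the source reports. "The series", "measured", "known", "first", "only" and "open" are said of these compounds alone.

Measured so far in an ADME assay on microsomes from liver (Mus musculus) for metabolic stability, read by LC-MS, with NADPH named in the record, with a stated time of 60 min, tested at 1 uM, in the absence of a further agent; a lower number here means that less of the compound is left, a higher number that more of the compound is left:
Compound 1 `COc1ccc(-c2c(C)nc3c(N4CC[C@@H](NC(C)=O)C4)cc(C)nn23)cc1OC` gives > 95%, which is a limit of the assay.
Compound 2 `COc1ccc(-c2c(C)nc3c(N4CC[C@@H](NS(=O)(=O)c5ccccc5)C4)cc(C)nn23)cc1OC` gives > 95%, which is a limit of the assay.
Compound 3 `COc1ccc(-c2c(C)nc3c(N4CC[C@@H](NS(=O)(=O)c5ccc(C)cc5)C4)cc(C)nn23)cc1OC` gives > 95%, which is a limit of the assay.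

Because every value sits at the limit of > 95% in this assay, at which 3 of the 3 values shown sit, none of the three steps can be sized: a step that the two limits leave unreadable from compound 1 to compound 2, a step that the two limits leave unreadable from compound 1 to compound 3 and a step that the two limits leave unreadable from compound 3 to compound 2.

Compound 3 and compound 2 differ in one place (hydrogen in place of methyl on an aromatic carbon). Compound 4 `COc1ccc(-c2cnc3c(N4CC[C@@H](NC(C)=O)C4)cc(C)nn23)cc1OC`, not yet measured, carries the same kind of change on the core of compound 1 (hydrogen in place of methyl on an aromatic carbon), but the surroundings differ: in compound 3 the methyl sits on an aromatic carbon of a six-membered aromatic ring of carbon only, para to a large group, whereas in compound 1 it sits on an aromatic carbon of a five-membered aromatic ring with 2 nitrogen, part of a fused or bridged system of two rings, next to the ring nitrogen. The two cores also differ (acetyl in place of (4-methylphenyl)sulfonyl on an amine nitrogen).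

Beside the unreadable earlier step that the two limits leave unreadable from compound 3 to compound 2, the step from compound 1 to compound 4 in this assay is expected to be a step that the limit leaves unreadable from compound 1 to compound 4, resting on compound 1 sitting at the limit of > 95% in this assay, at which 3 of the 3 values shown sit. Compound 4 is expected to give 97%.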

Compound 4, percent of the compound remaining: > 95%
Compound 4 gave a limit, no number; the forecaster's own chance of this, stated with the estimate: 75%; the middle value is on the limit's open side.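

In this assay compound 4 gives > 95%, which is a limit of the assay. No size can be read for the change from compound 1 to compound 4: the limit of > 95% in this assay, at which 4 of the 4 values shown sit.

The compounds shown leave open whether swapping methyl for hydrogen, or changing the group on the amine nitrogen, alters the amount of compound remaining at all.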